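Cytotoxicity notes: hydroxybutyl in place of propylbutyl

The compounds below may be only part of what the source reports. "The series", "measured", "known", "first", "only" and "open" are said of these compounds alone.

In an ADME assay on MT4 cells (Homo sapiens) for cytotoxicity, read by MTT assay, with a stated time of 5 days (a lower number here means that less compound is tolerated, a higher number that more compound is tolerated), compound 1 `COc1cc2cc(C#N)ccc2c(OC)c1Oc1cc(NC(C)C)nc(Nc2ccc(C#N)cc2)n1` gives only a limit, > 125000 nM. Compound 2 `CCC(C)Nc1cc(Oc2c(OC)cc3cc(C#N)ccc3c2OC)nc(Nc2ccc(C#N)cc2)n1` likewise gives only a limit, > 125000 nM. Compound 3 `CCCC(CCC)Nc1cc(Oc2c(OC)cc3cc(C#N)ccc3c2OC)nc(Nc2ccc(C#N)cc2)n1` also stands at a limit, > 125000 nM. All three values sit at the limit of > 125000 nM in this assay, at which 3 of the 3 values shown sit, so the steps a step that the two limits leave unreadable from compound 1 to compound 2, a step that the two limits leave unreadable from compound 1 to compound 3 and a step that the two limits leave unreadable from compound 2 to compound 3 have no readable size, and compound 3 stands at the same limit as the other two without any separation. Compound 4 `COc1cc2cc(C#N)ccc2c(OC)c1Oc1cc(NCCCCO)nc(Nc2ccc(C#N)cc2)n1` differs from compound 3 by 4-hydroxybutyl in place of 1-propylbutyl on a nitrogen on an aromatic ring. Every measured step changes the substituent on the nitrogen on the aromatic ring and none has a readable size, so the expected step of a number no higher from compound 3 to compound 4 (the limit leaves the size open) is none beyond the scatter. Compound 4 is therefore expected to stand at 125000 nM, within 60000 nM to 250000 nM, most probably again as a limit.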

Compound 4, half-maximal cytotoxic concentration: 39100 nM
The estimate for compound 4 lay 3.2-fold (0.50 log units) above the measured number; measured number below the stated range.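

In this assay the substituent on the nitrogen on the aromatic ring can move the read-out: 4-hydroxybutyl gives a number where the three alkyl groups give none, with steps of (an at least 3.1-fold lower number from compound 3 to compound 4 (0.50 log units; beyond the scatter)), (an at least 3.1-fold lower number from compound 2 to compound 4 (0.50 log units; beyond the scatter)) and (an at least 3.1-fold lower number from compound 1 to compound 4 (0.50 log units; beyond the scatter)). Each of these sizes is a minimum, as the other end of each step is a limit. The steps among compound 1, compound 2 and compound 3 remain unreadable, and these three stay unseparated at that limit: the limit of > 125000 nM in this assay, at which 3 of the 4 values shown sit.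

Going by these compounds, whether the terminal hydroxyl or the unbranched chain carries the step stays open, as 4-hydroxybutyl differs from the alkyl groups in both. An unbranched butyl chain or a 4-aminobutyl group would separate these readings.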